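The compounds below may be only part of what the source reports. "The series", "measured", "known", "first", "only" and "open" are said of these compounds alone.

Measured so far:
Compound 1 `CC1(C)Cc2c(sc(NC(=O)c3cccnc3O)c2C(N)=O)C(C)(C)O1` — 190 nM in an assay on cells for positive allosteric modulation of Cystic fibrosis transmembrane conductance regulator variant F508del (Homo sapiens), with stated times of 10 min and 7 s, in the presence of a further agent that is not named here; a higher number here means that more compound is needed for the effect, a lower number that less compound is needed
Compound 2 `CC1(C)Cc2c(sc(NC(=O)C3CCNC3=O)c2C(N)=O)C(C)(C)O1` — 101 nM in this assay

Compound 2 holds the lowest of the two numbers in this assay. Among the measured compounds shown here, its only neighbour is compound 1, and the step of a 1.9-fold lower number from compound 1 to compound 2 (0.27 log units; within the scatter) lies within the scatter, so the two compounds cannot be put in order on these data.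

Compound 3 `CC1(C)Cc2c(sc(NC(=O)[C@@H](O)C(C)(C)C)c2C(N)=O)C(C)(C)O1` differs from compound 2 in one place: 1-hydroxy-2,2-dimethylpropyl in place of 2-oxopyrrolidin-3-yl on a carbonyl carbon. For the measured compounds named here, the only measured step, a 1.9-fold lower number from compound 1 to compound 2 (0.27 log units; within the scatter), exchanged one ring-bearing group for another at this same carbonyl carbon and left the number essentially unchanged. Going by the values given here, no measured step covers a switch to a group without a ring, so there is no basis for a direction. Compound 3 is therefore expected to sit near compound 2, with a step of about a 1.2-fold higher number from compound 2 to compound 3 (0.07 log units; within the scatter) that stays within the scatter, and its estimated value is 120 nM in this assay, in a range from 40 nM to 400 nM.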

Compound 3, half-maximal effective concentration: 2.7 nM
For compound 3 the middle estimate is 44-fold (1.65 log units) above the measured one, outside the stated range (below it).
By their numbers in this assay, from the lowest: compound 3; then compounds 2 and 1 (each within the scatter of the next).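

In this assay the carbonyl carbon proves far from indifferent to its substituent: the two ring-bearing groups could not be told apart, but the open-chain 1-hydroxy-2,2-dimethylpropyl group gives a 37-fold lower number from compound 2 to compound 3 (1.57 log units; beyond the scatter) and a 70-fold lower number from compound 1 to compound 3 (1.85 log units; beyond the scatter). The 2-oxopyrrolidin-3-yl and 1-hydroxy-2,2-dimethylpropyl groups have equal counts of heavy atoms, hydrogen-bond donors and hydrogen-bond acceptors, so those counts do not separate them; they differ in the ring, in nitrogen against carbon, and in the defined stereocentre. Nothing available here accounts for the size of this drop.

The compounds shown leave open whether the hydroxy group is needed, as an amine or a plain hydrogen in its place would test. They also leave open how the opposite stereocentre or a smaller chain such as 1-hydroxyethyl would compare.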